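This account rests on a few compounds, and the source may have more. Where it says the series, first, only, none or still open, it means among the compounds named here.

Compound 1 `COc1cc(OC)c(OC)cc1/C=C/C(=O)c1cc(Cc2ccccc2)cc(Cc2ccccc2)c1`: 26900 nM
Compound 2 `COc1cc(OC)c(OC)cc1/C=C/C(=O)c1ccc(O)cc1O`: 37600 nM

In a functional assay on HeLa cells (Homo sapiens) for inhibition, read by MTT assay, with a stated time of 72 h (on this read-out lower numbers stand for stronger inhibition and higher numbers for weaker inhibition), compound 2 gives 37600 nM, which lies within the usual scatter of compound 1 at 26900 nM, so the two cannot be ranked. Compound 3 `COc1cc(OC)c(OC)cc1/C=C/C(=O)c1ccc(Br)cc1` has not yet been measured. Its structure differs from that of compound 2 as follows: 4-bromophenyl in place of 2,4-dihydroxyphenyl on a carbonyl carbon. That is, 4-bromophenyl stands in place of 2,4-dihydroxyphenyl on a carbonyl carbon. For the measured compounds named here, no measured pair shows this swap alone. Compound 1 also carries a different group on the carbonyl carbon and still reads 26900 nM, so no large change is expected in this assay. The estimated step of a 1.9-fold lower number from compound 2 to compound 3 (0.27 log units; within the scatter) is small and points towards a lower number. Compound 3 is expected at 20000 nM, within an estimated range of 6000 nM to 60000 nM.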

Compound 3, half-maximal inhibitory concentration: 31700 nM
Beside the measured number, compound 3's estimate is 1.6-fold (0.20 log units) below it; the measured number falls inside the stated range.
By their numbers in this assay, from the lowest: compounds 1, 3 and 2 (each within the scatter of the next).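

In this assay, for the compounds shown here, putting 4-bromophenyl in place of 2,4-dihydroxyphenyl on a carbonyl carbon gives a 1.2-fold lower number from compound 2 to compound 3 (0.07 log units; within the scatter), the first direct reading of this swap. The group that leaves carries hydrogen-bond donors and acceptors and the group that enters carries none, yet the two compounds cannot be told apart on this read-out. Nothing available explains this result. Still open, going by these compounds, is whether an aminophenyl or a carboxyphenyl group on this carbonyl carbon would give a number clearly apart from these.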